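The compounds below may be only part of what the source reports. "The series", "measured", "known", "first", "only" and "open" are said of these compounds alone.

In an assay for inhibition of sodium- and chloride-dependent glycine transporter 1 (Homo sapiens) (a lower number here means a stronger inhibitor, a higher number a weaker inhibitor), compound 1 `COc1ccc(Sc2ccc(Cl)cc2N2CCN(CC(=O)O)C(C)C2)cc1` gives 290 nM, the lowest of the two numbers obtained so far. Among the compounds with values here, its only measured neighbour is compound 2 `COc1ccc(Sc2ccccc2N2CCN(CC(=O)O)C(C)C2)cc1`, which in this assay gives 1700 nM; the move to hydrogen in place of chloro on an aromatic carbon produced a 5.9-fold higher number from compound 1 to compound 2 (0.77 log units; beyond the scatter). Compound 3 `COc1ccc(Sc2ccc(Cl)cc2N2CC(C)N(CC(=O)O)CC2C)cc1` has not yet been measured. It differs from compound 1 by methyl in place of hydrogen on a saturated ring carbon, that is, a methyl in place of hydrogen on a saturated ring carbon of the shared core, next to the ring nitrogen. Within the data shown here, the one measured step, from compound 1 to compound 2, concerns the chloro on the aromatic ring and does not touch the saturated ring, so no measured step bears on this change. With nothing to point in either direction, the change from compound 1 to compound 3 is expected to stay within the scatter, as a 1.0-fold higher number from compound 1 to compound 3 (0.01 log units; within the scatter). Compound 3 is therefore estimated at 300 nM in this assay, with a range from 100 nM to 900 nM.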

Compound 3, half-maximal inhibitory concentration: 1700 nM
For compound 3 the middle estimate is 5.7-fold (0.75 log units) below the measured one, and the stated range ends below it.
By their numbers in this assay, from the lowest: compound 1; then compounds 2 and 3 (each within the scatter of the next).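

In this assay, a methyl in place of hydrogen on a saturated ring carbon, next to the ring nitrogen and next to the ring atom that bears a large group, gives a 5.9-fold higher number from compound 1 to compound 3 (0.77 log units; beyond the scatter), the first measured sign that this part of the shared core responds to substitution. Within the data shown here, until now the only measured change lay on the aromatic ring, as the chloro step a 5.9-fold higher number from compound 1 to compound 2 (0.77 log units; beyond the scatter) shows, and it said nothing about the saturated ring; the new step shows that one added methyl, three ring bonds from the ring atom that already bears a methyl group, is enough to move the number beyond the scatter. No supporting data on hand explain this rise.

The compounds shown leave open whether the higher number is particular to methyl at this carbon or would also appear with a longer chain such as ethyl, or with a hydroxymethyl group. They also leave open whether the step would be the same without the chloro, or with the existing methyl on the ring taken away.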